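This account rests on a few compounds, and the source may have more. Where it says the series, first, only, none or still open, it means among the compounds named here.

This account follows a small group of compounds examined in an ADME assay on Vero cells (Chlorocebus sabaeus) for cytotoxicity, read by MTT assay, with a stated time of 72 h; on this read-out higher numbers stand for lower toxicity in this test and lower numbers for higher toxicity in this test. The starting point is compound 1 `Nc1nc(-c2ccccc2)cc(-c2ccc(C3NC(=O)c4ccccc4N3)cc2)n1`, but it offers no number to build on, since the entry for compound 1 reads "not determined" (no result reported). Compound 2 `CC1(c2ccc(Nc3nc(N4CCCc5ccccc54)nc(N4CCCc5ccccc54)n3)cc2)NC(=O)c2ccccc2N1`, which is built quite differently, also has no result, and its entry for compound 2 reads "not determined" (no result reported). For the measured compounds named here, compound 3 `COc1ccc(C(Nc2ccc(C3(C)NC(=O)c4ccccc4N3)cc2)c2nnnn2C(C)(C)C)cc1` is the only one with a reading, and compound 3 gives > 400000 nM, which is a limit of this assay and not a number.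

Compound 4 `Nc1nc(-c2ccc(Br)cc2)cc(-c2ccc(C3NC(=O)c4ccccc4N3)cc2)n1` changes compound 1 in one place: bromo in place of hydrogen on an aromatic carbon. Put simply, bromo takes the place of hydrogen on an aromatic carbon, para to a large group, so that a phenyl becomes a 4-bromophenyl.

Going by the values given here, no measured pair here shows what this swap does in this assay, so any expected step is a judgement. A modest step toward lower numbers seems likely, perhaps hardly beyond the usual scatter. Among the compounds with values here, the only anchor is compound 3, with its limit of > 400000 nM, and its structure differs considerably, so it is a loose guide. The expected half-maximal cytotoxic concentration of compound 4 is 250000 nM, with an estimated range from 60000 nM to 400000 nM.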

Compound 4, half-maximal cytotoxic concentration: > 400000 nM
Compound 4 gave a limit, no number; the forecaster's own chance of this, stated with the estimate: 50%; middle value at least 1.6-fold (0.20 log units) from the limit.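

In this assay compound 4 gives > 400000 nM, which is a limit of the assay and not a number. For the compounds shown here, compound 1 has no reported result, and no step from compound 1 to compound 4 can be read. This limit recurs here: the limit of > 400000 nM in this assay, at which 2 of the 4 values shown sit.

The compounds shown leave open whether bromo in place of hydrogen changes cytotoxicity in this test at all.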